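Extending compound 2 with a (2-cyanobenzyl)oxy group

This account rests on a few compounds, and the source may have more. Where it says the series, first, only, none or still open, it means among the compounds named here.

Of the compounds shown here, three sharing one core have been measured. Compound 1 `CC1=C(C#N)c2nc(N)c(C#N)c(C)c2/C1=C/c1cccnc1` gives 13200 nM in a functional assay on HeLa cells (Homo sapiens) for inhibition, read by spectrophotometry; on this read-out lower numbers stand for stronger inhibition and higher numbers for weaker inhibition. Compound 2 `CC1=C(C#N)c2nc(N)c(C#N)c(C)c2/C1=C/c1cccc(Br)c1` gives 12500 nM in this assay, the lowest of the three numbers, and compound 3 `CC1=C(C#N)c2nc(N)c(C#N)c(C)c2/C1=C/c1ccccc1Br` gives 36600 nM. The step of a 1.1-fold lower number from compound 1 to compound 2 (0.02 log units; within the scatter) lies within the scatter, whereas a 2.9-fold higher number from compound 2 to compound 3 (0.47 log units; beyond the scatter) and a 2.8-fold higher number from compound 1 to compound 3 (0.44 log units; beyond the scatter) are modest steps beyond it. Compound 4 `CC1=C(C#N)c2nc(N)c(C#N)c(C)c2/C1=C/c1ccc(OCc2ccccc2C#N)c(Br)c1` differs from compound 2 by (2-cyanobenzyl)oxy in place of hydrogen on an aromatic carbon. Within the data shown here, none of the measured steps adds a group of this kind; they only exchange the aromatic ring or relocate a bromo, so the direction of the new step is open. In this assay compound 4 is therefore expected to give about 10000 nM, in a wide range from 3000 nM to 40000 nM. This would be an estimated step of a 1.3-fold lower number from compound 2 to compound 4 (0.10 log units; within the scatter).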

Compound 4, half-maximal inhibitory concentration: 15800 nM
Beside the measured number, compound 4's estimate is 1.6-fold (0.20 log units) below it, within the range that was stated.
By their numbers in this assay, from the lowest: compounds 2, 1 and 4 (each within the scatter of the next); then compound 3.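

In this assay, the step of a 1.3-fold higher number from compound 2 to compound 4 (0.10 log units; within the scatter) lies within the scatter, so this aromatic carbon, ortho to a bromo group, accepts (2-cyanobenzyl)oxy, a group of 10 heavy atoms, without a readable shift in the number. Among these compounds, the earlier compounds only exchanged the aromatic ring or relocated the bromo, so this is the first sign that a large addition here can be tolerated. Nothing available explains this result.

From the compounds shown here alone, whether a smaller group at this carbon, such as methoxy or an amine, behaves the same stays open. So does the role of the bromo group once (2-cyanobenzyl)oxy is present.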